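The source may hold more compounds than are shown below. What is called first, only, known or untested is meant among the compounds shown, and "the series" means these compounds.

Working notes on the series. The parent core, compound 1 `O=C1C=CC(=O)c2ncncc21`, gives 18000 nM in a functional assay on PANC-1 cells (Homo sapiens) for cytotoxicity, read by MTT assay, with a stated time of 72 h; on this read-out higher numbers stand for weaker inhibition and lower numbers for stronger inhibition. Adding an anilino group carrying a phenoxy substituent gives compound 2 `O=C1C(Nc2ccc(Oc3ccccc3)cc2)=CC(=O)c2ncncc21`, which in this assay gives 1800 nM, the lowest of the two numbers so far and well beyond the scatter from compound 1. Compound 3 `O=C1C(Nc2ccc(-c3ccccc3)cc2)=CC(=O)c2ncncc21` is not yet measured; it differs from compound 2 by phenyl in place of phenoxy on an aromatic carbon. Going by the values given here, no step of this kind has been measured here, so no change beyond the scatter is expected, and the estimated step of a 1.4-fold higher number from compound 2 to compound 3 (0.14 log units; within the scatter) is small. Compound 3 is expected to give about 2500 nM, within 900 nM to 7000 nM.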

Compound 3, half-maximal inhibitory concentration: 400 nM
Estimate against measurement, compound 3: 6.3-fold (0.80 log units) above; measured number below the stated range.
By their numbers in this assay, from the lowest: compound 3; then compound 2; then compound 1.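

On the aromatic carbon of the anilino ring, the outer substituent matters to the read-out: in this assay phenyl in place of phenoxy gives a 4.5-fold lower number from compound 2 to compound 3 (0.65 log units; beyond the scatter) and so shows that this position responds to a change as small as losing the oxygen link while the outer ring stays. No measurement shown here accounts for this step. The compounds shown leave open how a smaller group such as methyl, or an amine or a carboxylic acid on the same aromatic carbon, would compare with phenyl.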